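The source may hold more compounds than are shown below. What is called first, only, known or untested is meant among the compounds shown, and "the series" means these compounds.

Compound 1 `COc1ccc(/C=C2/C(=O)N(c3ccc(Cl)cc3)N=C2C)cc1OC` and compound 2 `COc1ccc(/C=C2/C(=O)N(c3ccc(Cl)cc3)N=C2C)cc1Br` share one core and differ only in one substituent. In an assay for inhibition of Alpha amylase (Homo sapiens), with a stated time of 10 min (on this read-out higher numbers stand for weaker inhibition and lower numbers for stronger inhibition), compound 1 gives 2030 nM, and compound 2 gives 1920 nM; the step of a 1.1-fold lower number from compound 1 to compound 2 (0.02 log units; within the scatter) is within the scatter, so neither compound stands apart from the other. Compound 3 `COc1cc(/C=C2/C(=O)N(c3ccc(Cl)cc3)N=C2C)ccc1OC(C)=O` differs from compound 1 by acetyl in place of methyl on an oxygen on an aromatic ring. For the measured compounds named here, no measured step touches that oxygen; the only known step, a 1.1-fold lower number from compound 1 to compound 2 (0.02 log units; within the scatter), alters a different spot and stays within the scatter. In this assay compound 3 is therefore expected to give 2000 nM, between 800 nM and 5000 nM, an estimated step of a 1.0-fold lower number from compound 1 to compound 3 (0.01 log units; within the scatter).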

Compound 3, half-maximal inhibitory concentration: 1940 nM
Estimate against measurement, compound 3: 1.0-fold (0.01 log units) above; low and high end bracket the measured number.
By their numbers in this assay, from the lowest: compounds 2, 3 and 1 (each within the scatter of the next).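

In this assay the first change shown at this oxygen, methoxy to acetoxy, gives a 1.0-fold lower number from compound 1 to compound 3 (0.02 log units; within the scatter) even though acetyl brings more heavy atoms than methyl and adds a hydrogen-bond acceptor. At this oxygen, then, the swap from methyl to acetyl leaves the number without any shift beyond the scatter. No measurement shown explains this result.

Still open, as far as these compounds go, is whether a group that differs more from methyl, such as a longer chain, an amine or a carboxylic acid, would shift the number at this oxygen.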